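The source may hold more compounds than are shown below. What is called first, only, known or untested is meant among the compounds shown, and "the series" means these compounds.

Compound 1 `Nc1ccccc1NC(=O)c1ccc(CSC(=S)N2CCN(c3ccc(Cl)cc3)CC2)cc1`: in a functional assay on A-375 cells (Homo sapiens) for antiproliferative activity, read by CCK-8 assay, with a stated time of 72 h, tested at 8 uM (a lower number here means a weaker effect, a higher number a stronger effect of the compound at the concentration tested), compound 1 gives 29%.
Compound 2 `Nc1ccccc1NC(=O)c1ccc(CSC(=S)N2CCN(C3CCCCC3)CC2)cc1`: in this assay compound 2 gives 89.9%.
Compound 3 `COc1ccc(N2CCN(C(=S)SCc3ccc(C(=O)Nc4ccccc4N)cc3)CC2)cc1`: in this assay compound 3 gives 35.9%.

Compound 3 stands second highest of the three numbers; it lies within the scatter of compound 1, as a number 6.9 percentage points higher from compound 1 to compound 3 (within the scatter) shows, and well below compound 2, as a number 54 percentage points lower from compound 2 to compound 3 (beyond the scatter) shows. Compound 4 `Nc1ccccc1NC(=O)c1ccc(CSC(=S)N2CCN(c3ccc(F)cc3)CC2)cc1` differs from compound 3 in one place: fluoro in place of methoxy on an aromatic carbon. The step that bears on this change is a number 6.9 percentage points higher from compound 1 to compound 3 (within the scatter), a swap of one substituent on an aromatic carbon that stayed within the scatter; the large step of a number 60.9 percentage points higher from compound 1 to compound 2 (beyond the scatter) concerns the cyclohexyl group and does not apply here. No step beyond the scatter is therefore expected: a number 3.9 percentage points lower from compound 3 to compound 4 (within the scatter). Compound 4 is estimated at 32%, with a range from 15% to 50%.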

Compound 4, a percentage reported as inhibition, at one concentration (the size of the read-out at that concentration, not a potency): 76.3%
Beside the measured number, compound 4's estimate is 44.3 percentage points below it; measured number above the stated range.
By their numbers in this assay, from the lowest: compounds 1 and 3 (each within the scatter of the next); then compound 4; then compound 2.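

At this aromatic carbon, the substituent can matter strongly in this assay: fluoro in place of methoxy gives a number 40.4 percentage points higher from compound 3 to compound 4 (beyond the scatter), and fluoro in place of chloro gives a number 47.3 percentage points higher from compound 1 to compound 4 (beyond the scatter), although methoxy and chloro had not been separated. An aromatic ring on the amine nitrogen therefore does not by itself go with a low number, though 4-fluorophenyl in place of cyclohexyl still gives a number 13.6 percentage points lower from compound 2 to compound 4 (beyond the scatter). From the compounds shown here alone, whether a hydrogen, a nitrile or an amine at this carbon would behave like fluoro remains open. No measured evidence accounts for fluoro standing apart from chloro and methoxy.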